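A few compounds are considered here, and "the series" means these few. Any claim that something is new, unique, unknown or untested is made for them only; others in the source may bear on it.

Compound 1 `O=C1C(NC2CC2)=CC(=O)c2c1nc1n2[C@H]2OC[C@@H](O)[C@H]2OC1`: in a functional assay on MGC-803 cells (Homo sapiens) for inhibition, read by sulforhodamine B assay (on this read-out lower numbers stand for stronger inhibition and higher numbers for weaker inhibition), compound 1 reaches only a limit of the assay, > 4000 nM.
Compound 2 `COc1cccc(NC2=CC(=O)c3nc4n(c3C2=O)[C@H]2OC[C@@H](O)[C@H]2OC4)c1`: in this assay compound 2 gives 1780 nM.
Compound 3 `O=C1C=C(NC2CCCC2)C(=O)c2c1nc1n2[C@H]2OC[C@@H](O)[C@H]2OC1`: in this assay compound 3 reaches only a limit of the assay, > 8000 nM.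

Compound 1 thus stands at a limit rather than at a number, so its place among the three cannot be fixed more closely. Among the compounds with values here, the only measured number belongs to compound 2, which carries a 3-methoxyphenyl on the amine nitrogen. Within the data shown here, the single measured step, an at least 4.4-fold higher number from compound 2 to compound 3 (0.65 log units; beyond the scatter), shows that replacing that group with cyclopentyl weakened inhibition markedly. Compound 4 `O=C1C(N2CCC2)=CC(=O)c2c1nc1n2[C@H]2OC[C@@H](O)[C@H]2OC1` differs from compound 1 by azetidin-1-yl in place of cyclopropylamino on a double-bonded ring carbon. Among the measured compounds shown here, no measured step covers this swap. Compound 1 carries cyclopropylamino and sits at a limit. Compound 3 carries cyclopentyl on the amine nitrogen and likewise sits at a limit. Small saturated groups on this position therefore give no sign of strong inhibition, and the step that the limit leaves unreadable from compound 1 to compound 4 is expected to be none beyond the scatter. Compound 4 is estimated at 6000 nM, within 2500 nM to 20000 nM, and quite possibly the assay will again report only a limit.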

Compound 4, half-maximal inhibitory concentration: > 16000 nM
Compound 4: no number, only a limit (the forecaster's own chance of this, stated with the estimate: 65%); at least 2.6-fold (0.42 log units) between middle value and limit.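

Compound 1 and compound 4 each reach only a limit in this assay, and the step between them cannot be read. The compounds shown leave open whether azetidin-1-yl or cyclopropylamino on the double-bonded ring carbon gives stronger inhibition, and what actual value either compound has.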